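The source may hold more compounds than are shown below. What is called first, only, known or untested is meant among the compounds shown, and "the series" means these compounds.

Compound 2 `O=C(OCCc1ccc(Cl)c(Cl)c1)N(c1ccccc1)C1CN2CCC1CC2` is one of three close relatives that share a core and differ only in the group hanging from the oxygen next to the carbonyl. In an assay on CHO cells for displacement of a labelled ligand from muscarinic acetylcholine receptor M5 (Homo sapiens), read by scintillation counting, with a stated time of 2 h (a higher number here means a weaker inhibitor, a lower number a stronger inhibitor), compound 2 gives 80 nM. Compound 3 `O=C(OCc1ccc(Cl)c(Cl)c1)N(c1ccccc1)C1CN2CCC1CC2` gives 60 nM, and compound 1 `COc1ccc(COC(=O)N(c2ccccc2)C2CN3CCC2CC3)cc1F` gives 40 nM. Compound 2 sits at the high end of these three numbers, but only by a 1.3-fold lower number from compound 2 to compound 3 (0.12 log units; within the scatter) and a 2.0-fold higher number from compound 1 to compound 2 (0.30 log units; within the scatter), so none of the three can be told apart with confidence.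

Compound 4 `COc1ccc(CCOC(=O)N(c2ccccc2)C2CN3CCC2CC3)cc1OC` has not yet been measured. Relative to compound 2 it changes as follows: 3,4-dimethoxyphenyl in place of 3,4-dichlorophenyl on a saturated chain carbon, two bonds along the chain from an oxygen next to a carbonyl group

Among the compounds with values here, the steps that bear on this are those among the measured three: a 1.5-fold higher number from compound 1 to compound 3 (0.18 log units; within the scatter), a 2.0-fold higher number from compound 1 to compound 2 (0.30 log units; within the scatter) and a 1.3-fold lower number from compound 2 to compound 3 (0.12 log units; within the scatter). In each of them the ring on the chain was exchanged, and each time the number moved within the scatter. A move no larger than the scatter is therefore expected here too, giving a 1.5-fold lower number from compound 2 to compound 4 (0.16 log units; within the scatter). Compound 4 is estimated at 55 nM, with a range from 20 nM to 160 nM.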

Compound 4, inhibition constant: 3490 nM
Compound 4: middle estimate off by 63-fold (1.80 log units), on the low side, and the stated range ends below it.
By their numbers in this assay, from the lowest: compounds 1, 3 and 2 (each within the scatter of the next); then compound 4.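

In this assay, 3,4-dimethoxyphenyl in place of 3,4-dichlorophenyl on a saturated chain carbon, two bonds along the chain from an oxygen next to a carbonyl group, gives a 44-fold higher number from compound 2 to compound 4 (1.64 log units; beyond the scatter) and so a much weaker inhibitor. The ring at this position therefore cannot be exchanged freely: the steps among compounds 1, 2 and 3 stayed within the scatter, but this one does not. Nothing available here explains the change.

Going by these compounds, it remains open whether a single methoxy group, with a chlorine as the other ring substituent, would bring the same loss, or whether it takes both methoxy groups. Also open, on these data alone, are how an amine or a carboxylic acid on this ring would fare, and whether the shorter chain of compound 3 would respond in the same way.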